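A Furan Swap and Its Expected Effect on Edema Inhibition

This account rests on a few compounds, and the source may have more. Where it says the series, first, only, none or still open, it means among the compounds named here.

Compound 1 `COc1ccc(/C=C/C(=O)c2ccc(NC(=O)CO[N+](=O)[O-])cc2)cc1`, compound 2 `O=C(CO[N+](=O)[O-])Nc1ccc(C(=O)/C=C/c2ccco2)cc1` and compound 3 `COc1ccc(/C=C/C(=O)c2ccc(NC(=O)C(C)Br)cc2)cc1` were tested in a functional assay on the whole organism (strain albino) for inhibition, with Rattus norvegicus as the target, read by paw edema, with stated times of 30 min and 3 h, at a dose of 100 mg/kg by the oral route; a lower number here means less inhibition, a higher number more inhibition at the dose given (going by the name of the read-out). Compound 1 gives 53%, compound 2 gives 48%, and compound 3 gives 40%. The two cores of compound 1 and compound 3 differ in one place, (1-bromoethyl in place of (nitrooxy)methyl on a carbonyl carbon), which made a step of a number 13 percentage points lower from compound 1 to compound 3 (beyond the scatter). Compound 1 and compound 2 differ by furan-2-yl in place of 4-methoxyphenyl on a double-bonded chain carbon bound to a double-bonded chain carbon, which made a step of a number 5 percentage points lower from compound 1 to compound 2 (within the scatter). The unmeasured compound 4 `CC(Br)C(=O)Nc1ccc(C(=O)/C=C/c2ccco2)cc1` carries the same change relative to compound 3, namely (furan-2-yl in place of 4-methoxyphenyl on a double-bonded chain carbon bound to a double-bonded chain carbon). Because the earlier step of a number 5 percentage points lower from compound 1 to compound 2 (within the scatter) was small, compound 4 is expected to land close to compound 3, with an estimated step of a number 5 percentage points lower from compound 3 to compound 4 (within the scatter). Compound 4 is therefore estimated at 35%, with a likely range from 22% to 48%.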

Compound 4, a percentage reported as inhibition, in the whole organism at one dose (the size of the read-out at that dose, not a potency): 42%
Compound 4: the middle estimate sits 7 percentage points below what was measured, and the stated range covers the measured number.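

In this assay, furan-2-yl in place of 4-methoxyphenyl gave a number 2 percentage points higher from compound 3 to compound 4 (within the scatter), and the two readings of this change do not differ: the same change on two cores in this assay, a number 5 percentage points lower (within the scatter) from compound 1 to compound 2 and a number 2 percentage points higher (within the scatter) from compound 3 to compound 4, 7 percentage points apart, within the scatter of two such steps. Likewise, 1-bromoethyl in place of (nitrooxy)methyl gave a number 6 percentage points lower from compound 2 to compound 4 (within the scatter), and its two readings do not differ either: the same change on two cores in this assay, a number 13 percentage points lower (beyond the scatter) from compound 1 to compound 3 and a number 6 percentage points lower (within the scatter) from compound 2 to compound 4, 7 percentage points apart, within the scatter of two such steps. So both changes carried from one core to the other within the scatter, but this rests on only four compounds at one dose, and it does not show that the furan-2-yl swap alters inhibition at all.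

Going by these compounds, it remains open how a carboxylic acid or an amine would behave on the double-bonded chain carbon. On these data alone, it also remains open whether a longer chain on the carbonyl carbon would follow the 1-bromoethyl result.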